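The source may report more compounds than this note shows. Statements on the series, on what has been measured and on what is new or still open speak of the compounds shown alone.

These compounds were tested in a functional assay on CCRF-CEM cells (Homo sapiens) for inhibition; on this read-out lower numbers stand for stronger inhibition and higher numbers for weaker inhibition. Compound 1, with the structure `COc1cccc(/C=C2\CCCc3ccccc3C2=O)c1OC`, gives 142000 nM. Compound 2, with the structure `O=C1/C(=C/c2ccccc2Br)CCCc2ccccc21`, gives 32100 nM, which is the lower of the two numbers, and the gap to compound 1 is wider than the usual scatter of repeated measurements. Compound 3, with the structure `COc1ccccc1/C=C1\CCCc2ccccc2C1=O`, has not yet been measured. Compared with compound 2, the change is methoxy in place of bromo on an aromatic carbon. Because compound 1, which carries methoxy groups, gives 142000 nM while compound 2 gives 32100 nM, the step from bromo to methoxy is expected to weaken inhibition somewhat, and the estimated step is a 1.9-fold higher number from compound 2 to compound 3 (0.27 log units; within the scatter). For compound 3 in this assay the estimate is 60000 nM, with a range from 20000 nM to 180000 nM.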

Compound 3, half-maximal inhibitory concentration: 28900 nM
Estimate against measurement, compound 3: 2.1-fold (0.32 log units) above; low and high end bracket the measured number.
By their numbers in this assay, from the lowest: compounds 3 and 2 (each within the scatter of the next); then compound 1.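

In this assay, methoxy in place of bromo at this position, ortho to a large group, gives a 1.1-fold lower number from compound 2 to compound 3 (0.05 log units; within the scatter), so the two groups cannot be told apart here, despite their difference in size. Hydrogen in place of the further methoxy group of compound 1 gives a 4.9-fold lower number from compound 1 to compound 3 (0.69 log units; beyond the scatter), a modest step beyond the scatter, which shows that the gap between compound 1 and compound 2 goes with that further methoxy group and not with the methoxy group that compound 1 shares with compound 3. No measurement here accounts for either step.

As far as these compounds go, whether any group at this position would shift the number remains open, since only bromo and methoxy appear there. An amine or a carboxylic acid in the same place could show whether this position tolerates very different groups.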